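Swapping a Triazole for a Fluoropyridine on a Shared Core

The source may hold more compounds than are shown below. What is called first, only, known or untested is meant among the compounds shown, and "the series" means these compounds.

Compound 2 `Cc1ccc(-c2cc(C(=O)N[C@H](C)c3ccc(F)cn3)cc(-n3nccn3)c2)nc1` gives 3910 mL/min/kg in an ADME assay on the whole organism for metabolic stability, with Rattus norvegicus as the target (a higher number here means faster removal of the compound, a lower number slower removal), the second highest of the three numbers shown. Compound 3 `Cc1ccc(-c2cc(C(=O)N[C@H](C)c3ccc(C(F)(F)F)[n+]([O-])c3)cc(C(C)(C)O)c2)cc1` gives 6790 mL/min/kg in this assay, and that gap is within the scatter, while compound 1 `C[C@@H](NC(=O)c1cc(-c2ccc(F)cn2)cc(C(C)(C)O)c1)c1ccc(C(F)(F)F)[n+]([O-])c1` gives 477 mL/min/kg in this assay, well beyond it. Compound 4 `Cc1ccc(-c2cc(C(=O)N[C@H](C)c3ccc(F)cn3)cc(-c3ncccc3F)c2)nc1` differs from compound 2 by 3-fluoropyridin-2-yl in place of 2H-1,2,3-triazol-2-yl on an aromatic carbon. Going by the values given here, the only measured step that swaps one aromatic ring for another is a 14-fold higher number from compound 1 to compound 3 (1.15 log units; beyond the scatter), yet it sits at a different place on the core, so it guides only loosely. With no closer comparison, an expected step of a 1.0-fold lower number from compound 2 to compound 4 (0.00 log units; within the scatter) seems fair, a change that need not exceed the scatter. Compound 4 is therefore estimated at 3900 mL/min/kg in this assay, between 1500 mL/min/kg and 10000 mL/min/kg.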

Compound 4, clearance: 24800 mL/min/kg
Compound 4: the middle estimate sits 6.4-fold (0.80 log units) below what was measured; the whole stated range lies below it.
By their numbers in this assay, from the lowest: compound 1; then compounds 2 and 3 (each within the scatter of the next); then compound 4.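

At this place on the shared core, meta to a 5-methylpyridin-2-yl group, the identity of the aromatic ring clearly matters in this assay: the step of a 6.3-fold higher number from compound 2 to compound 4 (0.80 log units; beyond the scatter) comes with 3-fluoropyridin-2-yl in place of 2H-1,2,3-triazol-2-yl. The earlier ring swap lay elsewhere on the core, so it could not show this. Nothing given here explains the rise.

As far as these compounds go, whether the ring size or the fluorine carries the step remains open. A plain pyridin-2-yl or an amine at this place would help separate these possibilities.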